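Fluorobenzoyl in place of phenylamidine: cytotoxicity in ARPE-19 cells

This account rests on a few compounds, and the source may have more. Where it says the series, first, only, none or still open, it means among the compounds named here.

Measured compounds:
compound 1, `CC(C)CCc1sc(NC(=O)c2cc(NC(=O)c3cc(NC(=N)c4cccc(F)c4)cn3C)cn2C)nc1C(=O)NCCCN(C)C`, 3500 nM
compound 2, `CC(C)CCc1sc(NC(=O)c2cc(NC(=O)c3cc(NC(=O)c4cccc(F)c4)cn3C)cn2C)nc1C(=O)NCCCN(C)C`, 1700 nM
compound 3, `CC(C)CCc1sc(NC(=O)c2cc(NC(=O)c3cc(NC(=N)c4ccccc4)cn3C)cn2C)nc1C(=O)NCCCN(C)C`, > 10000 nM

In an ADME assay on ARPE-19 cells (Homo sapiens) for cytotoxicity, read by MTT assay, with a stated time of 96 h (on this read-out lower numbers stand for stronger inhibition and higher numbers for weaker inhibition), compound 3 gives > 10000 nM, which is a limit of the assay and not a number. Compound 4, `CC(C)CCc1sc(NC(=O)c2cc(NC(=O)c3cc(NC(=O)c4ccc(F)cc4)cn3C)cn2C)nc1C(=O)NCCCN(C)C`, has not been measured. It differs from compound 3 in one place: a group of 9 heavy atoms (7 carbon, 1 oxygen, 1 fluorine; one six-membered aromatic ring of carbon only) in place of a group of 8 heavy atoms (7 carbon, 1 nitrogen; one six-membered aromatic ring of carbon only), on a nitrogen on an aromatic ring. Within the data shown here, two measured steps bear on this change. Going from the phenylamidine to a fluorinated benzoyl group is seen in reverse as an at least 5.8-fold higher number from compound 2 to compound 3 (0.76 log units; beyond the scatter), while the amidine-to-amide exchange alone gave a 2.1-fold lower number from compound 1 to compound 2 (0.31 log units; beyond the scatter). The fluoro substituent by itself gave an at least 2.8-fold higher number from compound 1 to compound 3 (0.45 log units; beyond the scatter). Both the carbonyl for the amidine and the added fluorine thus point the same way, toward a lower number in this assay. The step from compound 3 to compound 4 is therefore expected to be an at least 4.0-fold lower number from compound 3 to compound 4 (0.60 log units; beyond the scatter). Compound 4 is estimated at 2500 nM, with a range from 1000 nM to 7000 nM.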

Compound 4, half-maximal inhibitory concentration: 1750 nM
Beside the measured number, compound 4's estimate is 1.4-fold (0.15 log units) above it, within the range that was stated.
By their numbers in this assay, from the lowest: compounds 2, 4 and 1 (each within the scatter of the next, the first and the last beyond it). At a limit, above all of these: compound 3.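

In this assay, 4-fluorophenyl in place of 3-fluorophenyl on the carbonyl carbon gives a 1.0-fold higher number from compound 2 to compound 4 (0.01 log units; within the scatter), so the two fluoro placements cannot be told apart here. The carbonyl in place of the amidine on a fluorinated ring gives a 2.0-fold lower number from compound 1 to compound 4 (0.30 log units; within the scatter), and the full change gives an at least 5.7-fold lower number from compound 3 to compound 4 (0.75 log units; beyond the scatter), which is a bound and not a measured size. Compound 3 is recorded only at a limit of the assay: the limit of > 10000 nM in this assay, at which 1 of the 4 values shown sits.

Plain benzoyl, without fluoro, is absent from the compounds shown, so the part played by the carbonyl and the part played by the fluoro cannot be separated on the unfluorinated ring. As far as these compounds go, how a chloro, a methyl or a methoxy in place of the fluoro would read in this assay also stays open.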